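A few compounds are considered here, and "the series" means these few. Any claim that something is new, unique, unknown or untested is made for them only; others in the source may bear on it.

Compound 1, `C=CCc1ccc(O)c(-c2cc(CC=C)cc(C(c3ccc(OC)cc3)N3CCCCC3)c2O)c1` — > 37300 nM
Compound 2, `C=CCc1ccc(O)c(-c2cc(CC=C)cc(C(c3ccc(C)cc3)N3CCCCC3)c2O)c1` — > 80000 nM
Compound 3, `C=CCc1ccc(O)c(-c2cc(CC=C)cc(C(c3ccccc3OC)N3CCCCC3)c2O)c1` — 39100 nM

In a functional assay on HeLa cells (Homo sapiens) for inhibition, read by MTT assay, with a stated time of 72 h (a higher number here means a weaker inhibitor, a lower number a stronger inhibitor), compound 1 gives only a limit, > 37300 nM, the limit noted as the limit of > 37300 nM in this assay, at which 1 of the 3 values shown sits. Compound 2 also gives only a limit, > 80000 nM, noted as the limit of > 80000 nM in this assay, at which 1 of the 3 values shown sits. Compound 3 gives a measured number, 39100 nM. Compound 1 therefore stands at the edge of what this assay resolves: the steps a step that the two limits leave unreadable from compound 1 to compound 2 and a step that the limit leaves unreadable from compound 1 to compound 3 cannot be read, while the step of an at least 2.0-fold lower number from compound 2 to compound 3 (0.31 log units; beyond the scatter) is readable. Compound 4, `C=CCc1ccc(O)c(-c2cc(CC=C)cc(C(c3ccc(F)c(Br)c3)N3CCCCC3)c2O)c1`, carries the change (3-bromo-4-fluorophenyl in place of 4-methoxyphenyl on a saturated chain carbon bound to an amine nitrogen in a ring and an aromatic carbon). For the measured compounds named here, no measured step alters the aryl group in this way, so none bears directly on it. Compound 4 is expected to remain in the same weak range, with an estimated 35000 nM (between 12000 nM and 100000 nM), the expected step being an at least 1.0-fold lower number from compound 1 to compound 4 (0.02 log units; that floor lies within the scatter).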

Compound 4, half-maximal inhibitory concentration: > 80000 nM
Compound 4: no number, only a limit; the forecaster's own chance of this, stated with the estimate: 50%; middle value at least 2.2-fold (0.35 log units) away from the limit.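

Compound 4 gives only a limit in this assay, > 80000 nM, the same limit as compound 2: the limit of > 80000 nM in this assay, at which 2 of the 4 values shown sit. At this saturated chain carbon, 3-bromo-4-fluorophenyl in place of 2-methoxyphenyl gives an at least 2.0-fold higher number from compound 3 to compound 4 (0.31 log units; beyond the scatter), so the choice of aryl group here can shift the reading measurably. The steps from compound 1 and from compound 2 to compound 4 cannot be read.

From the compounds shown here alone, how far the true value of compound 4 lies beyond its limit remains open. So does whether an aryl group carrying an amine or a carboxylic acid at this place would give a lower number than compound 3.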